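The source may hold more compounds than are shown below. What is called first, only, known or untested is meant among the compounds shown, and "the series" means these compounds.

Measured in a functional assay, read by spectrophotometry; a higher number here means that more compound is needed for the effect, a lower number that less compound is needed:
compound 1 `COc1cc(-c2cc(=O)c3ccc(O)cc3o2)cc(OC)c1OC`: 26.4 nM
compound 2 `COc1ccc(-c2cc(=O)c3ccc(OCCCN4CCC(C)CC4)cc3o2)cc1`: 26.6 nM
compound 3 `COc1ccc(-c2cc(=O)c3ccc(OCCCN4CCC(C)CC4)cc3o2)cc1OC`: 24.1 nM

Compound 3 sits level with the other two compounds, since all three values lie within the scatter of one another. The next compound is compound 4 `COc1cc(-c2cc(=O)c3ccc(OCCCN4CCC(C)CC4)cc3o2)cc(OC)c1OC`, which differs from compound 3 as follows: methoxy in place of hydrogen on an aromatic carbon. The new methoxy stands ortho to a methoxy group.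

One measured step is of the same kind, methoxy in place of hydrogen on an aromatic carbon: a 1.1-fold lower number from compound 2 to compound 3 (0.04 log units; within the scatter). That is a single step, and it stays within the scatter. Compound 4 also shares its methoxy groups with compound 1, at 26.4 nM, although the two differ elsewhere on the core. No step beyond the scatter is therefore expected in this assay, and no direction can be assigned. The estimated step is a 1.0-fold higher number from compound 3 to compound 4 (0.02 log units; within the scatter). For compound 4 the expected value is 25 nM, with an estimated range of 11 nM to 55 nM.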

Compound 4, half-maximal effective concentration: 26.8 nM
Estimate against measurement, compound 4: 1.1-fold (0.03 log units) below; low and high end bracket the measured number.
By their numbers in this assay, from the lowest: compounds 3, 1, 2 and 4 (each within the scatter of the next).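

In this assay, going by these compounds alone, a further methoxy ortho to a methoxy group gives a 1.1-fold higher number from compound 3 to compound 4 (0.05 log units; within the scatter), so this position takes the group without a step beyond the scatter, as the one earlier methoxy step also did. Within the data shown here, the 3-(4-methylpiperidin-1-yl)propyl group in place of hydrogen on the oxygen gives a 1.0-fold higher number from compound 1 to compound 4 (0.01 log units; within the scatter), the first single-change reading of that chain, and it also stays within the scatter. No measured evidence bears on why neither change moves the number beyond the scatter.

From the compounds shown here alone, whether a hydroxy or ethoxy group at this position would move the number stays open, as does the effect of a longer chain or a morpholine in place of the 4-methylpiperidine. With all four compounds within the scatter, the series does not yet show which part of the structure affects the read-out in this assay.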